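Cyclopentyl to cyclohexyl on the aromatic nitrogen

This account rests on a few compounds, and the source may have more. Where it says the series, first, only, none or still open, it means among the compounds named here.

Within the data shown here, in an ADME assay on C8166 cells (Homo sapiens) for cytotoxicity, read by MTT assay (a lower number here means that less compound is tolerated, a higher number that more compound is tolerated), compound 2 (`O=C(O)c1cn(C2CCCC2)c2ccc(Cc3cccc(Cl)c3F)c(O)c2c1=O`) gives 12400 nM and holds the lower of the two numbers so far. Compound 1 (`CC(C)n1cc(C(=O)O)c(=O)c2c(O)c(Cc3cccc(Cl)c3F)ccc21`) stands higher, with 26500 nM on the same read-out. Compound 3 (`O=C(O)c1cn(C2CCCCC2)c2ccc(Cc3cccc(Cl)c3F)c(O)c2c1=O`) differs from compound 2 in one place, with cyclohexyl in place of cyclopentyl on an aromatic nitrogen. Among the measured compounds shown here, only one measured step bears on this change: cyclopentyl in place of isopropyl at the same nitrogen (a 2.1-fold lower number from compound 1 to compound 2 (0.33 log units; beyond the scatter)), which is modest but beyond the scatter. For the measured compounds named here, a single step establishes no trend, and no measured compound yet carries a cyclohexyl group. A small further move in the same direction is therefore expected, and it may not clear the scatter (a 1.3-fold lower number from compound 2 to compound 3 (0.12 log units; within the scatter)). Compound 3 is estimated at 9500 nM (expected range 4500 nM to 20000 nM).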

Compound 3, half-maximal cytotoxic concentration: 17400 nM
Beside the measured number, compound 3's estimate is 1.8-fold (0.26 log units) below it; the range from low to high includes it.
By their numbers in this assay, from the lowest: compounds 2, 3 and 1 (each within the scatter of the next, the first and the last beyond it).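

In this assay cyclohexyl on the aromatic nitrogen gives a 1.4-fold higher number from compound 2 to compound 3 (0.15 log units; within the scatter) and so does not extend the earlier step from isopropyl to cyclopentyl, a 2.1-fold lower number from compound 1 to compound 2 (0.33 log units; beyond the scatter) in the same direction. Measured against isopropyl directly, cyclohexyl gives a 1.5-fold lower number from compound 1 to compound 3 (0.18 log units; within the scatter) and so compound 3 cannot be separated from either compound 1 or compound 2, even though those two stand apart; across these three groups the number does not follow ring size or heavy-atom count in any steady way. No measurement at hand explains these differences.

Still open, as far as these compounds go, is whether a linear hexyl chain, or a piperidine ring in place of the cyclohexyl carbons, would move the number beyond the scatter. Also open, from the compounds shown here alone, is whether these small steps at the nitrogen would hold on a core without the carboxylic acid.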